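A few compounds are considered here, and "the series" means these few. Any claim that something is new, unique, unknown or untested is made for them only; others in the source may bear on it.

Measured compounds:
- compound 1, `N#Cc1ccc(Nc2nc(Oc3c(Br)cc(Br)cc3Br)c3ccccc3n2)cc1`: 58000 nM
- compound 2, `N#Cc1ccc(Nc2nc(Oc3c(Cl)cc(Cl)cc3Cl)c3ccccc3n2)cc1`: 56000 nM
- compound 3, `Cc1ccccc1Oc1nc(Nc2ccc(C#N)cc2)nc2ccccc12`: 355000 nM

These three compounds share a core and differ only in the ring that hangs from an oxygen on that core. They were tested in an ADME assay on MT4 cells (Homo sapiens) for cytotoxicity, read by MTT assay, with a stated time of 4 days; on this read-out higher numbers stand for lower toxicity in this test and lower numbers for higher toxicity in this test. Compound 1 stands second highest of the three numbers; compound 2 sits nearest to it, with a 1.0-fold lower number from compound 1 to compound 2 (0.02 log units; within the scatter), while compound 3 lies furthest away, with a 6.1-fold higher number from compound 1 to compound 3 (0.79 log units; beyond the scatter). The same picture appears in a 6.3-fold higher number from compound 2 to compound 3 (0.80 log units; beyond the scatter).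

Compound 4, `Cc1cccc(Oc2nc(Nc3ccc(C#N)cc3)nc3ccccc23)c1`, has not yet been measured in this assay. Its change from compound 1 is 3-methylphenyl in place of 2,4,6-tribromophenyl on an oxygen on an aromatic ring. Going by the values given here, the step that bears most directly on it is the one from compound 1 to compound 3, where a single methyl-bearing ring took the place of the tribromophenyl and the number rose modestly. Compound 4 carries the same kind of ring, with the methyl in another position, so a rise of similar size is expected, estimated as a 5.2-fold higher number from compound 1 to compound 4 (0.71 log units; beyond the scatter). The value of compound 4 in this assay is therefore estimated at 300000 nM, with a range from 120000 nM to 700000 nM.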

Compound 4, half-maximal cytotoxic concentration: 355000 nM
For compound 4 the middle estimate is 1.2-fold (0.07 log units) below the measured one, and the stated range covers the measured number.
By their numbers in this assay, from the lowest: compounds 2 and 1 (each within the scatter of the next); then compounds 3 and 4 (each within the scatter of the next).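

Shifting the methyl group on the ring attached to the oxygen makes no visible difference in this assay: there is no change at the digits printed from compound 3 to compound 4 (within the scatter), so 2-methylphenyl and 3-methylphenyl cannot be told apart here. The new ring also shows the same gap to the halogen-bearing rings as 2-methylphenyl, with a 6.1-fold higher number from compound 1 to compound 4 (0.79 log units; beyond the scatter) and a 6.3-fold higher number from compound 2 to compound 4 (0.80 log units; beyond the scatter). Among these four compounds, then, the numbers divide by whether the ring carries three halogens or one methyl, and the place of the methyl does not shift them.

No measurement here explains why the two kinds of ring differ. As far as these compounds go, it also remains open whether a ring carrying a single bromine, an amine or a carboxylic acid would fall with the methyl-bearing rings or with the 2,4,6-tribromophenyl and 2,4,6-trichlorophenyl rings.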